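Hydrazone Replacement at the Amide Nitrogen of Compound 3

This account rests on a few compounds, and the source may have more. Where it says the series, first, only, none or still open, it means among the compounds named here.

Measured so far in an ADME assay on cells (Splenocyte, Mus musculus, strain BALB/c) for cytotoxicity, read by thymidine incorporation, with a stated time of 24 h; on this read-out higher numbers stand for weaker inhibition and lower numbers for stronger inhibition:
compound 1, `COc1cc(/C=N/NC(=O)CCN2CCN(c3ccnc4cc(Cl)ccc34)CC2)ccc1OC(C)=O`, 15800 nM
compound 2, `O=C(CCN1CCN(c2ccnc3cc(Cl)ccc23)CC1)N/N=C/c1c[nH]c2ccccc12`, 5700 nM
compound 3, `NNC(=O)CCN1CCN(c2ccnc3cc(Cl)ccc23)CC1`, > 100000 nM

Compound 3 stands apart from the other two. Its result in this assay is a limit of the assay rather than a number, the same limit recorded in the limit of > 100000 nM in this assay, at which 1 of the 3 values shown sits. Compound 4, `O=C(CCN1CCN(c2ccnc3cc(Cl)ccc23)CC1)N/N=C/c1ccccc1O`, is not yet measured; it differs from compound 3 by a group of 9 heavy atoms (7 carbon, 1 nitrogen, 1 oxygen; one six-membered aromatic ring of carbon only) in place of one nitrogen atom, on an amide-type nitrogen.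

Among the compounds with values here, one measured step bears on this change directly: an at least 17-fold higher number from compound 2 to compound 3 (1.24 log units; beyond the scatter), where the hydrazone group was stripped away to leave the bare amino group. Within the data shown here, the step in the other direction, putting a hydrazone back, is the one compound 4 makes. The change from compound 1 to compound 2 shows that the aromatic part of the hydrazone also matters, a 2.8-fold lower number from compound 1 to compound 2 (0.44 log units; beyond the scatter), a modest difference. The account therefore expects a large fall in the number, back into the range where compounds 1 and 2 sit, and estimates an at least 6.6-fold lower number from compound 3 to compound 4 (0.82 log units; beyond the scatter). For compound 4 in this assay the estimate is 15000 nM, with a range from 4000 nM to 60000 nM.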

Compound 4, half-maximal inhibitory concentration: 11500 nM
For compound 4 the middle estimate is 1.3-fold (0.12 log units) above the measured one; the range from low to high includes it.
By their numbers in this assay, from the lowest: compounds 2, 4 and 1 (each within the scatter of the next, the first and the last beyond it). At a limit, above all of these: compound 3.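

In this assay, placing the 2-hydroxyphenyl hydrazone on the amide-type nitrogen gives an at least 8.6-fold lower number from compound 3 to compound 4 (0.93 log units; beyond the scatter), so the lower number at this position is not confined to the two aromatic groups seen before. The entry for compound 3 is a limit of the assay, so the size of this step is only a bound: the limit of > 100000 nM in this assay, at which 1 of the 4 values shown sits. Among the hydrazones, the results are a 2.0-fold higher number from compound 2 to compound 4 (0.30 log units; within the scatter) and a 1.4-fold lower number from compound 1 to compound 4 (0.14 log units; within the scatter), and as both lie within the scatter, 2-hydroxyphenyl cannot be ranked against 1H-indol-3-yl or 4-acetoxy-3-methoxyphenyl.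

The compounds shown leave open whether the aromatic ring is needed at all, since every hydrazone here carries one and a methyl group in its place would test this. They also leave open whether the double bond matters, which an acetyl group on the amide-type nitrogen would address.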